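The source may report more compounds than this note shows. Statements on the series, on what has been measured and on what is new or still open speak of the compounds shown alone.

Measured compounds:
compound 1 `c1cncc(CN[C@H]2C3C4CC5C6C4CC3C6C52)c1`, 508 nM
compound 2 `C1CCC(CN[C@H]2C3C4CC5C6C4CC3C6C52)CC1`, 4 nM
compound 3 `COc1ccc(CN(C)[C@H]2C3C4CC5C6C4CC3C6C52)cc1OC`, 255 nM

These three share one saturated core and differ in the group carried on the amine nitrogen. In an assay on brain for displacement of a labelled ligand from Sigma non-opioid intracellular receptor 1 (Rattus norvegicus) (a higher number here means a weaker inhibitor, a lower number a stronger inhibitor), compound 2 gives the lowest number of the three, with compound 3 next and compound 1 furthest away. Within the data shown here, the one step with a single change, a 130-fold lower number from compound 1 to compound 2 (2.10 log units; beyond the scatter), concerns the ring on the chain carbon, not the nitrogen. Compound 4 `CN(CC1CCCCC1)[C@H]1C2C3CC4C5C3CC2C5C41` takes a different route: methyl in place of hydrogen on an amine nitrogen. Among the measured compounds shown here, no measured step addresses this kind of change; compound 3 also carries a methyl on its nitrogen but differs from compound 2 elsewhere too, so its value alone cannot settle the question. Compound 4 is therefore expected to stay close to compound 2, with a step of a 2.0-fold higher number from compound 2 to compound 4 (0.30 log units; within the scatter), giving an estimate of 8 nM (range 2 nM to 40 nM).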

Compound 4, inhibition constant: 15 nM
Compound 4: middle estimate off by 1.9-fold (0.27 log units), on the low side; measured number inside the range.
By their numbers in this assay, from the lowest: compound 2; then compound 4; then compounds 3 and 1 (each within the scatter of the next).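

Among these compounds, this step gives the first direct reading of methyl in place of hydrogen on this amine nitrogen: a 3.8-fold higher number from compound 2 to compound 4 (0.57 log units; beyond the scatter). The change is modest, so this nitrogen can carry a methyl while the number stays in the low range seen for compound 2. Nothing available explains why the number rises.

Going by these compounds, whether an ethyl group or a longer chain on the nitrogen would raise the number further remains open. So does whether the same methyl step would hold with pyridin-3-yl in place of cyclohexyl.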